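Swapping the tail of compound 2 for an amide

The source may report more compounds than this note shows. Statements on the series, on what has been measured and on what is new or still open speak of the compounds shown alone.

Three compounds sharing one core were compared in an assay on brain for binding affinity to adenosine receptor A1 (Rattus norvegicus), read by radioligand binding; a lower number here means a stronger inhibitor, a higher number a weaker inhibitor. Compound 1, `CCCn1c(=O)c2nc(-c3ccc(OCC(=O)NCCN=C(S)Nc4ccc(C)cc4)cc3)[nH]c2n(CCC)c1=O`, gives 16 nM. Compound 2, `CCCn1c(=O)c2nc(-c3ccc(OCC(=O)NCCN=C(S)Nc4ccc(Br)cc4)cc3)[nH]c2n(CCC)c1=O`, gives 7.26 nM. Compound 3, `CCCn1c(=O)c2nc(-c3ccc(OCC(=O)NCCN=C(S)Nc4ccc(S(=O)(=O)O)cc4)cc3)[nH]c2n(CCC)c1=O`, gives 367 nM. Among these three numbers compound 2 stands lowest: the nearest is compound 1, reached by a 2.2-fold lower number from compound 1 to compound 2 (0.34 log units; beyond the scatter), and the furthest is compound 3, reached by a 51-fold higher number from compound 2 to compound 3 (1.70 log units; beyond the scatter). The step from compound 1 to compound 3 is likewise large, a 23-fold higher number from compound 1 to compound 3 (1.36 log units; beyond the scatter).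

The next compound, compound 4, is `CCCn1c(=O)c2nc(-c3ccc(OCC(=O)NCCNC(=O)c4ccc(CBr)cc4)cc3)[nH]c2n(CCC)c1=O`. It differs from compound 2 by a group of 11 heavy atoms (8 carbon, 1 nitrogen, 1 oxygen, 1 bromine; one six-membered aromatic ring of carbon only) in place of a group of 11 heavy atoms (7 carbon, 2 nitrogen, 1 sulfur, 1 bromine; one six-membered aromatic ring of carbon only), on a saturated chain carbon, two bonds along the chain from an amide-type nitrogen. None of the three measured steps touches this part of the molecule in the same way: each of them only exchanged a single substituent on the outer ring, while here the whole tail beyond the chain is replaced, with the bromine kept but now carried on a methylene. The measured steps therefore give only loose guidance; a change of this extent could move the number in either direction, and a modest step seems the most likely outcome.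

Compound 4 is estimated at 20 nM in this assay, within 5 nM to 80 nM, which would mean an expected 2.8-fold higher number from compound 2 to compound 4 (0.44 log units; beyond the scatter).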

Compound 4, inhibition constant: 11.5 nM
The estimate for compound 4 lay 1.7-fold (0.24 log units) above the measured number, within the range that was stated.
By their numbers in this assay, from the lowest: compounds 2, 4 and 1 (each within the scatter of the next, the first and the last beyond it); then compound 3.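

In this assay, among the compounds shown here, replacing the whole tail beyond the chain, a part of the molecule the earlier steps left untouched, gives a 1.6-fold higher number from compound 2 to compound 4 (0.20 log units; within the scatter), and set against the methyl-bearing tail the same kind of replacement gives a 1.4-fold lower number from compound 1 to compound 4 (0.14 log units; within the scatter). For the compounds shown here, at this place, on a saturated chain carbon, two bonds along the chain from an amide-type nitrogen, ((4-(bromomethyl)phenyl)carbonyl)amino can therefore take the place of either earlier tail with no change beyond the scatter, whereas the earlier compounds showed only what exchanging a single substituent on the outer ring does. No measurement shown here accounts for this result.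

How a methyl, a bromo or a sulfo on the outer ring of this amide tail would compare with the bromomethyl group of compound 4 remains open, so the compounds shown cannot tell whether the large step seen with sulfo would recur in the amide series. What a longer chain in the tail of compound 4, or a carboxylic acid on its outer ring, would do to the number is equally unknown.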